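Changing the group on the sulfonyl sulfur: compound 4

This account rests on a few compounds, and the source may have more. Where it says the series, first, only, none or still open, it means among the compounds named here.

Three sulfonamides built on one shared core have been run in a functional assay on MIA PaCa-2 cells (Homo sapiens) for inhibition, read by MTT assay, with a stated time of 72 h; on this read-out higher numbers stand for weaker inhibition of growth and lower numbers for stronger inhibition of growth. Compound 1 `O=[N+]([O-])c1ccc(S(=O)(=O)NCCCCCCNCc2ccc(Br)cc2)cc1` gives 9800 nM. Compound 2 `COc1ccc(S(=O)(=O)NCCCCCCNCc2ccc(Br)cc2)cc1` gives 13000 nM. Compound 3 `O=S(=O)(NCCCCCCNCc1ccc(Br)cc1)c1ccccc1F` gives 13300 nM, and since the steps of a 1.4-fold higher number from compound 1 to compound 3 (0.13 log units; within the scatter) and a 1.0-fold higher number from compound 2 to compound 3 (0.01 log units; within the scatter) both lie within the scatter, compound 3 stands nowhere apart from its two companions. Compound 4 `O=S(=O)(NCCCCCCNCc1ccc(Br)cc1)c1c(Cl)cccc1Cl` differs from compound 3 in one place: 2,6-dichlorophenyl in place of 2-fluorophenyl on a sulfonyl sulfur. The two steps just named bear on this change, as each also exchanged the group on the sulfonyl sulfur, and neither moved the read-out beyond the scatter, so no step beyond the scatter is expected in this assay here either. Compound 4 is therefore expected to give 13000 nM (range 5000 nM to 35000 nM), an expected step of a 1.0-fold lower number from compound 3 to compound 4 (0.01 log units; within the scatter).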

Compound 4, concentration for 50% growth inhibition: 14700 nM
For compound 4 the middle estimate is 1.1-fold (0.05 log units) below the measured one, within the range that was stated.
By their numbers in this assay, from the lowest: compounds 1, 2, 3 and 4 (each within the scatter of the next).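

Among the compounds shown here, the 2,6-dichlorophenyl group, with two chlorines where compound 3 carries one fluorine, is the first group on the sulfonyl sulfur with two substituents on its ring, and in this assay it still leaves the read-out within the scatter of every earlier compound (a 1.1-fold higher number from compound 3 to compound 4 (0.04 log units; within the scatter); a 1.1-fold higher number from compound 2 to compound 4 (0.05 log units; within the scatter); a 1.5-fold higher number from compound 1 to compound 4 (0.18 log units; within the scatter)). This position has therefore tolerated all four aromatic groups shown without a step beyond the scatter. No measurement at hand offers an explanation for this. Going by these compounds, what an amine or a carboxylic acid on the sulfonyl sulfur would give in this assay remains open, as does the effect of a longer chain in the shared core.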